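Swapping Bromophenyl Isomers in a Cytotoxicity Series

The source may hold more compounds than are shown below. What is called first, only, known or untested is meant among the compounds shown, and "the series" means these compounds.

Compound 1 `COc1cccc(/C=C2\CCC/C(=C\c3cccc(Br)c3)C2=O)c1OC` and compound 2 `COc1cccc(/C=C2\CCC/C(=C\c3ccc(Br)cc3)C2=O)c1OC` are built on one shared core. In a functional assay on SW-620 cells (Homo sapiens) for cytotoxicity, read by MTT assay, with a stated time of 72 h (on this read-out higher numbers stand for weaker inhibition and lower numbers for stronger inhibition), compound 1 gives 8800 nM, and compound 2 gives 11100 nM. The structural change between them is 4-bromophenyl in place of 3-bromophenyl on a double-bonded chain carbon bound to a double-bonded ring carbon, and it produced a 1.3-fold higher number from compound 1 to compound 2 (0.10 log units; within the scatter), so the two values cannot be told apart.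

Compound 3 `COc1ccc(/C=C2\CCC/C(=C\c3cccc(Br)c3)C2=O)cc1OC` carries a different core; the difference between the two cores is not broken down here. In this assay compound 3 gives 4200 nM, the lowest of the three measured numbers, and its gap to both compound 1 and compound 2 lies beyond the scatter.

Compound 4 `COc1ccc(/C=C2\CCC/C(=C\c3ccc(Br)cc3)C2=O)cc1OC` has not yet been measured. It differs from compound 3 by 4-bromophenyl in place of 3-bromophenyl on a double-bonded chain carbon bound to a double-bonded ring carbon, the same change that was made from compound 1 to compound 2. Because that earlier change gave a 1.3-fold higher number from compound 1 to compound 2 (0.10 log units; within the scatter), the step is expected to be small, about a 1.3-fold higher number from compound 3 to compound 4 (0.12 log units; within the scatter). On that basis compound 4 is estimated in this assay at 5500 nM, with an expected range from 2800 nM to 11000 nM.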

Compound 4, half-maximal inhibitory concentration: 5200 nM
Beside the measured number, compound 4's estimate is 1.1-fold (0.02 log units) above it, within the range that was stated.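

In this assay, putting 4-bromophenyl in place of 3-bromophenyl on the second core gave a 1.2-fold higher number from compound 3 to compound 4 (0.09 log units; within the scatter), so the two isomers cannot be told apart on this core either. Set side by side, the steps on the two cores do not differ: the same change on two cores in this assay, a 1.3-fold higher number (0.10 log units; within the scatter) from compound 1 to compound 2 and a 1.2-fold higher number (0.09 log units; within the scatter) from compound 3 to compound 4, 1.0-fold (0.01 log units) apart, within the scatter of two such steps. This shows that the exchange stayed within the scatter on both cores in this one cell assay, but it does not show that the same would hold on any other core, and a swap with so little effect is a weak test of whether a larger effect would carry over.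

The compounds shown leave open whether the same agreement would appear if an amine, a nitrile or a carboxylic acid took the place of the bromine on the phenyl ring. They also leave open which part of the difference between the two cores goes with the lower numbers of compound 3 and compound 4.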